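Swapping the methoxyphenyl of compound 3 for a difluorophenyl

The source may report more compounds than this note shows. Statements on the series, on what has been measured and on what is new or still open speak of the compounds shown alone.

Compound 3 `COc1ccc(C(=O)/C=C/c2cc(-c3cc(OC)c(OC)c(OC)c3)n[nH]2)cc1` gives -44% in a functional assay on MDA-MB-435 cells (Homo sapiens) for cytotoxicity, read by sulforhodamine B assay, with a stated time of 48 h, tested at 100 uM (on this read-out lower numbers stand for a stronger effect and higher numbers for a weaker effect at the one concentration tested), the second highest of the three numbers: compound 2 `COc1ccc(C(=O)/C=C/c2cc(-c3cc(OC)c(OC)c(OC)c3)n[nH]2)cc1OC` lies nearest at -73%, and compound 1 `COc1cc(-c2cc(/C=C/C(=O)c3ccc(Cl)c(Cl)c3)[nH]n2)cc(OC)c1OC` furthest at 6%. Compound 4 `COc1cc(-c2cc(/C=C/C(=O)c3ccc(F)c(F)c3)[nH]n2)cc(OC)c1OC` differs from compound 3 by 3,4-difluorophenyl in place of 4-methoxyphenyl on a carbonyl carbon. The step that bears on this is the one between dihalogen and methoxy on that carbonyl carbon: a number 50 percentage points lower from compound 1 to compound 3 (beyond the scatter), a large step; the move a number 79 percentage points lower from compound 1 to compound 2 (beyond the scatter) runs the same way. Compound 4 carries a dihalogenated ring like compound 1, so a large step back towards the weaker end is expected, a number 44 percentage points higher from compound 3 to compound 4 (beyond the scatter). For compound 4 the expected value is 0%, with a range from -40% to 30%.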

Compound 4, a percentage reported as activity, at one concentration (the size of the read-out at that concentration, not a potency): -34%
For compound 4 the middle estimate is 34 percentage points above the measured one, and the stated range covers the measured number.
By their numbers in this assay, from the lowest: compound 2; then compounds 3 and 4 (each within the scatter of the next); then compound 1.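

In this assay, a dihalogenated ring at this position does not by itself bring a weak read-out: 3,4-difluorophenyl in place of 4-methoxyphenyl gives a number 10 percentage points higher from compound 3 to compound 4 (within the scatter), whereas 3,4-difluorophenyl in place of 3,4-dichlorophenyl gives a number 40 percentage points lower from compound 1 to compound 4 (beyond the scatter). The two halogens therefore part, and the fluorines sit with the single methoxy rather than with the chlorines. Replacing 3,4-dimethoxyphenyl with 3,4-difluorophenyl still gives a number 39 percentage points higher from compound 2 to compound 4 (beyond the scatter). Nothing available explains these steps. On these data alone, how a ring bearing one fluorine, or a dimethylamino group, would read at this carbonyl carbon stays open.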